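The compounds below may be only part of what the source reports. "The series", "measured", "known", "first", "only" and "open" are said of these compounds alone.

Values in a functional assay, with a stated time of 30 min; on this read-out lower numbers stand for stronger inhibition and higher numbers for weaker inhibition:
compound 1 `COc1ccc(C2CC(=NOC(=O)c3ccc([N+](=O)[O-])cc3)CC(c3ccc(OC)cc3)N2C)cc1`: 280000 nM
compound 2 `COc1ccc(C2CC(=NOC(=O)c3cc([N+](=O)[O-])cc([N+](=O)[O-])c3)CC(c3ccc(OC)cc3)N2C)cc1`: 312000 nM
compound 3 `COc1ccc(C2CC(=NOC(=O)c3cccc(O)c3)CC(c3ccc(OC)cc3)N2C)cc1`: 34000 nM

Compound 2 stands at the upper end of these three numbers; the gap a 1.1-fold higher number from compound 1 to compound 2 (0.05 log units; within the scatter) lies within the scatter, whereas a 9.2-fold lower number from compound 2 to compound 3 (0.96 log units; beyond the scatter). Compound 4 `COc1ccc(C2CC(=NOC(=O)c3ccc(OC)cc3OC)CC(c3ccc(OC)cc3)N2C)cc1` carries 2,4-dimethoxyphenyl in place of 3,5-dinitrophenyl on a carbonyl carbon. Within the data shown here, both steps that remove a nitro-bearing ring, an 8.2-fold lower number from compound 1 to compound 3 (0.92 log units; beyond the scatter) and a 9.2-fold lower number from compound 2 to compound 3 (0.96 log units; beyond the scatter), gave modest lowerings, and the one step that keeps nitro groups, a 1.1-fold higher number from compound 1 to compound 2 (0.05 log units; within the scatter), stayed within the scatter. Among the measured compounds shown here, no measured step pairs a nitro-bearing ring against a methoxy-bearing one, so the 2,4-dimethoxyphenyl itself is untested here. A modest lowering is therefore expected, smaller than for the hydroxy-bearing ring because only the removal side is supported by a 9.2-fold lower number from compound 2 to compound 3 (0.96 log units; beyond the scatter). For compound 4 the estimate is 100000 nM in this assay, between 30000 nM and 350000 nM, an expected step of a 3.1-fold lower number from compound 2 to compound 4 (0.49 log units; beyond the scatter).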

Compound 4, half-maximal inhibitory concentration: 80000 nM
Compound 4: the middle estimate sits 1.3-fold (0.10 log units) above what was measured, within the range that was stated.
By their numbers in this assay, from the lowest: compound 3; then compound 4; then compounds 1 and 2 (each within the scatter of the next).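

Among the nitro-free rings on the carbonyl carbon, the lowering in this assay is not confined to the 3-hydroxyphenyl: 2,4-dimethoxyphenyl, which has no hydrogen-bond donor, also gives a lower number against both nitro-bearing rings (a 3.9-fold lower number from compound 2 to compound 4 (0.59 log units; beyond the scatter) and a 3.5-fold lower number from compound 1 to compound 4 (0.54 log units; beyond the scatter)). The two nitro-free rings are still distinguishable, with 2,4-dimethoxyphenyl giving the higher number (a 2.4-fold higher number from compound 3 to compound 4 (0.37 log units; beyond the scatter)). Nothing available explains these differences.

Open, as far as these compounds go, is whether the lowering tracks loss of nitro or gain of hydroxy or methoxy. An unsubstituted phenyl ring, a single methoxy or an aminophenyl ring could separate these.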